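Replacing pyridin-3-yl at the aromatic carbon of compound 2

The source may hold more compounds than are shown below. What is called first, only, known or untested is meant among the compounds shown, and "the series" means these compounds.

In an ADME assay on SH-SY5Y cells (Homo sapiens) for cytotoxicity, read by MTT assay, with a stated time of 48 h (a higher number here means that more compound is needed for the effect, a lower number that less compound is needed), compound 2 `O=C(NCCCCCCCn1cc(-c2cccnc2)nn1)c1ccccc1-c1cccnc1` gives 36.5 nM and stands lowest, below compound 1 `NC(=O)c1ccccc1-c1ccccc1C(=O)NCCCCCCCn1cc(-c2cccnc2)nn1` at 289 nM so far. Compound 3 `CN(C)Cc1cn(-c2ccccc2C(=O)NCCCCCCCn2cc(-c3cccnc3)nn2)nn1` has 4-((dimethylamino)methyl)-1H-1,2,3-triazol-1-yl in place of pyridin-3-yl on an aromatic carbon of compound 2. Among the compounds with values here, the one measured step at this place (a 7.9-fold lower number from compound 1 to compound 2 (0.90 log units; beyond the scatter)) is modest and beyond the scatter, and pyridin-3-yl sits at its low end. Within the data shown here, no measured compound carries the new group here, so a smaller move toward a higher number is expected in this assay rather than a further fall. The expected size is a 2.7-fold higher number from compound 2 to compound 3 (0.44 log units; beyond the scatter) on present data. The estimate for compound 3 is 100 nM within an expected range of 25 nM to 400 nM in this series.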

Compound 3, half-maximal effective concentration: 285 nM
Compound 3: the middle estimate sits 2.9-fold (0.45 log units) below what was measured; the range from low to high includes it.
By their numbers in this assay, from the lowest: compound 2; then compounds 3 and 1 (each within the scatter of the next).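

In this assay, pyridin-3-yl now holds the low number against two different groups on this aromatic carbon, since 4-((dimethylamino)methyl)-1H-1,2,3-triazol-1-yl also loses it (a 7.8-fold higher number from compound 2 to compound 3 (0.89 log units; beyond the scatter)). The triazolyl group and 2-carbamoylphenyl cannot be told apart here (a 1.0-fold lower number from compound 1 to compound 3 (0.01 log units; within the scatter)), although they differ in structure. No available evidence accounts for this result.

Open: whether plain phenyl or a morpholine at this place stays near compound 2 or near compound 3, and whether a shorter chain alters the picture.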